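The compounds below may be only part of what the source reports. "The series", "measured", "known", "first", "only" and "open" are said of these compounds alone.

Compound 2 `COc1ccc(CN(C(=O)CSC(=S)N2CCOCC2)c2cc(OC)c(OC)c(OC)c2)cc1` carries the highest number of the two compounds measured in a functional assay on KYSE-450 cells (Homo sapiens) for inhibition, read by CCK-8 assay, with a stated time of 48 h; on this read-out higher numbers stand for weaker inhibition and lower numbers for stronger inhibition: compound 2 gives 7220 nM. Its nearest measured neighbour is compound 1 `COc1ccc(CN(C(=O)CSc2nc3ccccc3o2)c2cc(OC)c(OC)c(OC)c2)cc1`, which in this assay gives 840 nM, and the step of an 8.6-fold higher number from compound 1 to compound 2 (0.93 log units; beyond the scatter) lies beyond the scatter. Compound 3 `COc1ccc(CN(C(=O)CSC(=S)N2CCCc3cc(OC)ccc32)c2cc(OC)c(OC)c(OC)c2)cc1` differs from compound 2 by 6-methoxy-1,2,3,4-tetrahydroquinolin-1-yl in place of morpholin-4-yl on a thiocarbonyl carbon. Going by the values given here, the only measured step that bears on this change is an 8.6-fold higher number from compound 1 to compound 2 (0.93 log units; beyond the scatter), in which a group holding a six-membered aromatic ring of carbon only gave way to a group without one and the number rose. The change into compound 3 brings a six-membered aromatic ring of carbon only back, though on a thiocarbonyl carbon rather than on a sulfur, so a moderate step toward lower numbers is expected, a 2.9-fold lower number from compound 2 to compound 3 (0.46 log units; beyond the scatter). Compound 3 is therefore estimated at 2500 nM in this assay, with a range from 700 nM to 9000 nM.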

Compound 3, half-maximal inhibitory concentration: 5530 nM
Compound 3: middle estimate off by 2.2-fold (0.34 log units), on the low side, within the range that was stated.
By their numbers in this assay, from the lowest: compound 1; then compounds 3 and 2 (each within the scatter of the next).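

In this assay the change shows a 1.3-fold lower number from compound 2 to compound 3 (0.12 log units; within the scatter), so on this thiocarbonyl carbon 6-methoxy-1,2,3,4-tetrahydroquinolin-1-yl and morpholin-4-yl cannot be told apart, even though the first brings a six-membered aromatic ring of carbon only and the larger heavy-atom count. A six-membered aromatic ring of carbon only at this place is thus not enough to reach the level of compound 1, which gives 840 nM, and it does not account for the earlier step, an 8.6-fold higher number from compound 1 to compound 2 (0.93 log units; beyond the scatter). No measurement at hand offers a reason for this result.

From the compounds shown here alone, it remains open whether the thiocarbonyl carbon itself, rather than the group it carries, separates compound 1 from the other two. Going by these compounds, it is also open whether dimethylamino or piperidin-1-yl on that carbon would change the number in this assay.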